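The source may report more compounds than this note shows. Statements on the series, on what has been measured and on what is new or still open speak of the compounds shown alone.

Three related compounds have numbers in a functional assay on A549 cells (Homo sapiens) for antiproliferative activity, read by MTT assay, with a stated time of 72 h; on this read-out lower numbers stand for stronger inhibition and higher numbers for weaker inhibition. Compound 1 `COc1ncc(-c2ccc3c(c2)N(c2ccc(C)cc2)C(=O)CO3)cc1NS(=O)(=O)c1ccc(F)cc1` gives 5870 nM. Compound 2 `CC(C)N1C(=O)COc2ccc(-c3cnc(Cl)c(NS(=O)(=O)c4ccc(F)cc4)c3)cc21` gives 5100 nM. Compound 3 `COc1ncc(-c2ccc3c(c2)N(c2ccc(Cl)cc2)C(=O)CO3)cc1NS(=O)(=O)c1ccc(F)cc1` gives 8350 nM. The gaps from compound 3 to the other two lie within the scatter of repeated measurements, so the data do not separate it from either one.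

Compound 4 `COc1ncc(-c2ccc3c(c2)N(C(C)C)C(=O)CO3)cc1NS(=O)(=O)c1ccc(F)cc1` keeps the rest of compound 3 but carries isopropyl in place of 4-chlorophenyl on an amide-type nitrogen in a ring.

Within the data shown here, only one measured step between compounds differing in one place is available, a 1.4-fold higher number from compound 1 to compound 3 (0.15 log units; within the scatter). It swaps methyl for chloro on an aromatic carbon and stays within the scatter, but it says little about replacing the whole ring. Closer evidence comes from compound 2, which already has isopropyl on that nitrogen and differs from compound 4 by chloro in place of methoxy. Compound 2 gives 5100 nM. Neither comparison points to a large change, so no step beyond the scatter is expected in this assay.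

The estimated change is a 1.7-fold lower number from compound 3 to compound 4 (0.22 log units; within the scatter). For compound 4 the expected value is 5000 nM, with an estimated range of 1800 nM to 13000 nM.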

Compound 4, half-maximal inhibitory concentration: 4920 nM
Estimate against measurement, compound 4: 1.0-fold (0.01 log units) above; measured number inside the range.
By their numbers in this assay, from the lowest: compounds 4, 2, 1 and 3 (each within the scatter of the next).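

In this assay, replacing the whole aromatic ring on the amide-type nitrogen with isopropyl can now be read directly, and neither step leaves the scatter: a 1.7-fold lower number from compound 3 to compound 4 (0.23 log units; within the scatter) for 4-chlorophenyl and a 1.2-fold lower number from compound 1 to compound 4 (0.08 log units; within the scatter) for 4-methylphenyl. The earlier compounds shown here offered only a swap of methyl for chloro on that aromatic ring, whereas these steps show that this assay does not separate a substituent with a six-membered aromatic ring from isopropyl, which has no ring and fewer heavy atoms. With isopropyl held on the nitrogen, methoxy in place of chloro on an aromatic carbon also stays within the scatter, at a 1.0-fold lower number from compound 2 to compound 4 (0.02 log units; within the scatter), and no independent measurement is available here to explain any of these results.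

On these data alone, it remains open whether an amine, a carboxylic acid or a longer chain such as n-butyl on the amide-type nitrogen would produce a step beyond the scatter. These compounds also leave open how far the number can move through changes elsewhere on the shared core, such as an amine in place of the methoxy or chloro group.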